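This account rests on a few compounds, and the source may have more. Where it says the series, first, only, none or still open, it means among the compounds named here.

Compound 1 `Cc1nc(Nc2ccc(Cl)c(Cl)c2)sc1C(=O)/C=C/c1ccc(Cl)cc1` and compound 2 `Cc1nc(Nc2cccc(Cl)c2)sc1C(=O)/C=C/c1ccccc1` share one core and differ only in the chlorine pattern on their two outer rings. In a functional assay on PC-3 cells (Homo sapiens) for cytotoxicity, read by MTT assay (a higher number here means a weaker inhibitor, a lower number a stronger inhibitor), compound 1 reaches only the limit of the measurement, > 25000 nM. In this assay compound 2 likewise gives only a limit, > 25000 nM. Compound 2 therefore stands at the edge of what this measurement can report, and both values sit there (the limit of > 25000 nM in this assay, at which 2 of the 2 values shown sit). Compound 3 `Cc1nc(Nc2ccc(Cl)c(Cl)c2)sc1C(=O)/C=C/c1ccccc1` differs from compound 2 by chloro in place of hydrogen on an aromatic carbon. Compound 1 already carries that 3,4-dichlorophenyl and shows only the limit > 25000 nM. The expected step, a step that the limit leaves unreadable from compound 2 to compound 3, is none beyond the scatter. Compound 3 is expected at 35000 nM, ranging from 15000 nM to 100000 nM, most likely again reported as a limit.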

Compound 3, half-maximal inhibitory concentration: 7990 nM
Estimate against measurement, compound 3: 4.4-fold (0.64 log units) above; measured number below the stated range.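

The added chloro, ortho to a chloro group, counts in this assay: the change to 3,4-dichlorophenyl gives an at least 3.1-fold lower number from compound 2 to compound 3 (0.49 log units; beyond the scatter). That ring alone does not decide the outcome, for the other outer ring matters too: hydrogen in place of chloro there gives an at least 3.1-fold lower number from compound 1 to compound 3 (0.49 log units; beyond the scatter). Both steps are minimum sizes only, because each starts from a limit: the limit of > 25000 nM in this assay, at which 2 of the 3 values shown sit.

From the compounds shown here alone, whether a fluoro, a methoxy or an amine on this same carbon would act as chloro does stays open. So does the true size of either step.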